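Ethoxycarbonyl for (ethoxycarbonyl)amino on the shared core

The source may report more compounds than this note shows. Statements on the series, on what has been measured and on what is new or still open speak of the compounds shown alone.

Three members of the series have numbers in an assay on isolated protein (strain Sprague-Dawley) for inhibition of Amine oxidase [flavin-containing] B (Rattus norvegicus), read by spectrophotometry, with a stated time of 5 min; a lower number here means a stronger inhibitor, a higher number a weaker inhibitor. Compound 1 `COCOc1cc(=O)oc2cc(OCc3cccc(Cl)c3)ccc12` gives 100 nM, compound 2 `CCOC(=O)Nc1cc(=O)oc2cc(OCc3cccc(Cl)c3)ccc12` gives 589 nM, and compound 3 `O=c1cc(CCl)c2ccc(OCc3cccc(Br)c3)cc2o1` gives 209 nM. Going by the values given here, compound 2 stands highest of the three; its neighbour is compound 3, whose value sits clearly lower, and the single one-point step on record, a 5.9-fold higher number from compound 1 to compound 2 (0.77 log units; beyond the scatter), separates it further from compound 1.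

Compound 4 `CCOC(=O)c1cc(=O)oc2cc(OCc3cccc(Cl)c3)ccc12` is the next candidate for this assay. Its change from compound 2 is ethoxycarbonyl in place of (ethoxycarbonyl)amino on an aromatic carbon; the group that leaves carries a hydrogen-bond donor, the group that enters carries none.

Among the compounds with values here, no measured step swaps these two groups. Within the data shown here, the only step that bears on the position at all is the one in which the carbamate arrived, a 5.9-fold higher number from compound 1 to compound 2 (0.77 log units; beyond the scatter), and it worsened the number. Removing its donor is expected to give back part of that, so a modest improving step a 2.0-fold lower number from compound 2 to compound 4 (0.29 log units; within the scatter) is expected. Compound 4 is therefore estimated at 300 nM, with a range from 100 nM to 900 nM.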

Compound 4, half-maximal inhibitory concentration: 417 nM
Beside the measured number, compound 4's estimate is 1.4-fold (0.14 log units) below it, within the range that was stated.
By their numbers in this assay, from the lowest: compound 1; then compounds 3, 4 and 2 (each within the scatter of the next, the first and the last beyond it).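

In this assay the change from (ethoxycarbonyl)amino to ethoxycarbonyl gives a 1.4-fold lower number from compound 2 to compound 4 (0.15 log units; within the scatter) and so does not separate the two compounds: at this position, losing the hydrogen-bond donor has no effect that can be read. The other comparison gives a 4.2-fold higher number from compound 1 to compound 4 (0.62 log units; beyond the scatter) and so shows that the gap from compound 1 is not confined to (ethoxycarbonyl)amino, as methoxymethoxy stands apart from both groups that carry the ethyl ester-type carbonyl. No available evidence bears on the reason for this ordering.

Still open, going by these compounds, is how a free amine or a carboxylic acid on this aromatic carbon would compare with compound 1 and compound 4. Also open, on these data alone, is whether a plain methoxy or a longer alkoxymethoxy chain would keep the number of compound 1.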